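The source may report more compounds than this note shows. Statements on the series, on what has been measured and on what is new or still open speak of the compounds shown alone.

Two chalcone-type compounds carrying a triazole-linked benzyl ether have been measured in a functional assay on HepG2 cells (Homo sapiens) for inhibition, read by MTT assay, with a stated time of 48 h, tested at 10 uM; on this read-out higher numbers stand for more inhibition of growth at the one concentration tested and lower numbers for less inhibition of growth. Compound 1, `O=C(/C=C/c1ccc(OCc2cn(Cc3cccc(F)c3)nn2)cc1)c1ccc(Br)cc1`, pairs a 3-fluorobenzyl group on the triazole with a bromophenyl ketone, and in this assay compound 1 gives 34%. Compound 2, `O=C(/C=C/c1ccc(OCc2cn(Cc3cccc(Br)c3)nn2)cc1)c1ccc([N+](=O)[O-])cc1`, carries a 3-bromobenzyl group and a nitrophenyl ketone, and in this assay compound 2 gives 13%, the lower of the two numbers and a difference from compound 1 that lies beyond the scatter. The two compounds differ in two places at once, so their values alone do not tell which change carries the difference.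

Compound 3, `O=C(/C=C/c1ccc(OCc2cn(Cc3cccc(F)c3)nn2)cc1)c1ccc([N+](=O)[O-])cc1`, keeps the nitrophenyl ketone of compound 2 and changes only the halogen on the benzyl ring: fluoro in place of bromo on an aromatic carbon. Among the measured compounds shown here, no measured pair isolates this halogen swap, so there is no step to lean on. The expected change from compound 2 is small, of the order of the scatter, leaning slightly upward, estimated as a number 5 percentage points higher from compound 2 to compound 3 (within the scatter). Compound 3 is therefore expected to give about 18%, within a range from 5% to 35%.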

Compound 3, percent growth inhibition at one concentration: 43%
For compound 3 the middle estimate is 25 percentage points below the measured one; measured number outside the range, above it.
By their numbers in this assay, from the lowest: compound 2; then compounds 1 and 3 (each within the scatter of the next).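

In this assay, with the nitrophenyl ketone held fixed, fluoro in place of bromo on the benzyl ring gives a number 30 percentage points higher from compound 2 to compound 3 (beyond the scatter) and so shows that this position, meta to a large group, responds to the choice of halogen, at least with this ketone. With the 3-fluorobenzyl group held fixed, nitro in place of bromo on the phenyl ketone gives a number 9 percentage points higher from compound 1 to compound 3 (within the scatter) and so does not separate these two groups in this read-out, which means the ketone substituent need not be a drag on growth inhibition in itself. No measurement at hand offers a reason for the size of the halogen step.

From the compounds shown here alone, whether the halogen step carries over to the bromophenyl ketone stays open, as does how a chloro group, a methoxy group or an amine at the same place on the benzyl ring would read. Going by these compounds, all three values also come from a single concentration, so how these compounds would compare across a range of concentrations remains open as well.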